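A few compounds are considered here, and "the series" means these few. Any claim that something is new, unique, unknown or untested is made for them only; others in the source may bear on it.

Compound 3 `Cc1ccc(CCCN2CCc3nc(C)c([C@H](OC(C)(C)C)C(=O)O)c(-c4cc(F)c5c(c4C)CCCO5)c3C2)cc1F` is the point of departure. In an ADME assay on MT2 cells (Homo sapiens) for cytotoxicity, read by XTT assay, with a stated time of 4 days (on this read-out higher numbers stand for lower toxicity in this test and lower numbers for higher toxicity in this test), compound 3 gives > 40000 nM, which is a limit of the assay rather than a number. Two related compounds carry the same kind of reading. Compound 1 `Cc1ccc(-c2c3c(nc(C)c2[C@H](OC(C)(C)C)C(=O)O)CCN(c2ccc(-c4ccccc4)cc2)C3)cc1` in this assay gives > 40000 nM, again a limit. Compound 2 `Cc1nc2c(c(-c3cc(F)c4c(c3C)CCCO4)c1[C@H](OC(C)(C)C)C(=O)O)CN(CCCc1cccc(F)c1)CC2` in this assay gives > 40000 nM, also a limit. For the measured compounds named here, the only step between compounds that differ in one place, a step that the two limits leave unreadable from compound 2 to compound 3, cannot be sized because both ends are limits, as the limit of > 40000 nM in this assay, at which 3 of the 3 values shown sit, makes plain: every value shown sits at the same limit.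

Compound 4 `Cc1nc2c(c(-c3cc(F)c4c(c3C)CCCO4)c1[C@H](OC(C)(C)C)C(=O)O)CN(CCCc1ccc(F)cc1)CC2` is not yet measured and differs from compound 3 as follows: 4-fluorophenyl in place of 3-fluoro-4-methylphenyl on a saturated chain carbon, three bonds along the chain from an amine nitrogen in a ring. Going by the values given here, no measured step gives a readable size to lean on, so there is no ground to expect a step beyond the scatter in this assay in either direction. Compound 4 is therefore expected to give 45000 nM, with a range from 20000 nM to 100000 nM. The step this estimate means, a step that the limit leaves unreadable from compound 3 to compound 4, is expected to be essentially none, with another limit reading most likely.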

Compound 4, half-maximal cytotoxic concentration: > 40000 nM
Compound 4: no number, only a limit; the forecaster's own chance of this, stated with the estimate: 85%; the middle value is on the limit's open side.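

In this assay compound 4 gives > 40000 nM, which is a limit and not a number. The steps to it from compound 2 and from compound 3 cannot be read. The compounds shown leave open whether any of these changes alters the reading at all, because every value is the same limit: the limit of > 40000 nM in this assay, at which 4 of the 4 values shown sit.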